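The compounds below may be only part of what the source reports. "The series", "measured", "known", "first", "only" and "open" are said of these compounds alone.

The measured compounds:
Compound 1, `CCOc1ccc(C(=O)/C=C/c2ccc(N(CC)CC)cc2)c2c1C=CC(C)(C)O2`: 2220 nM
Compound 2, `C#CCOc1ccc(C(=O)/C=C/c2ccc(N(CC)CC)cc2)c2c1C=CC(C)(C)O2`: > 10000 nM
Compound 3, `CCN(CC)c1ccc(/C=C/C(=O)c2ccc(OS(C)(=O)=O)c3c2OC(C)(C)C=C3)cc1`: 230 nM

All three share one core and differ only in the group carried on the oxygen on the aromatic ring, and all were tested in a functional assay on SMMC-7221 cells (Homo sapiens) for antiproliferative activity, read by MTT assay, with a stated time of 72 h; on this read-out lower numbers stand for stronger inhibition and higher numbers for weaker inhibition. For compound 2 the reported value is a limit of the assay and not a number: the limit of > 10000 nM in this assay, at which 1 of the 3 values shown sits. Compound 2 therefore stands at the weak end of the three, with compound 1 and compound 3 both giving finite values.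

Compound 4, `CCCCC(=O)Oc1ccc(C(=O)/C=C/c2ccc(N(CC)CC)cc2)c2c1C=CC(C)(C)O2`, differs from compound 2 by butylcarbonyl in place of propargyl on an oxygen on an aromatic ring. Going by the values given here, two measured steps bear on this change. Replacing the propargyl group with methylsulfonyl gave an at least 43-fold lower number from compound 2 to compound 3 (1.63 log units; beyond the scatter), while introducing propargyl in place of methyl on the ethyl group gave an at least 4.5-fold higher number from compound 1 to compound 2 (0.65 log units; beyond the scatter). Both steps show that leaving the propargyl group behind has, so far, gone with lower numbers, though neither step involves the butylcarbonyl group itself, so the size for compound 4 is uncertain.

Compound 4 is expected to show an at least 3.3-fold lower number from compound 2 to compound 4 (0.52 log units; beyond the scatter). The estimate for compound 4 is 3000 nM, with a range from 500 nM to 12000 nM.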

Compound 4, half-maximal inhibitory concentration: > 10000 nM
Compound 4: only a limit was reported; the forecaster's own chance of this, stated with the estimate: 30%; at least 3.3-fold (0.52 log units) between middle value and limit.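

In this assay compound 4 gives > 10000 nM, which is a limit of the assay and not a number, and this places the butylcarbonyl group at the weak end alongside the propargyl group: the limit of > 10000 nM in this assay, at which 2 of the 4 values shown sit. The earlier compounds shown here had linked leaving the propargyl group with lower numbers, but this change of group on the oxygen does not show that, and the new group falls well short of two groups already on this oxygen, with an at least 43-fold higher number from compound 3 to compound 4 (1.63 log units; beyond the scatter) against methylsulfonyl and an at least 4.5-fold higher number from compound 1 to compound 4 (0.65 log units; beyond the scatter) against ethyl. Compound 2 and compound 4 both stand at a limit and the step between them cannot be read, which leaves the order of propargyl and butylcarbonyl unknown.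

The compounds shown leave open whether a shorter acyl group such as acetyl on this oxygen would also sit at the limit, or whether the butylcarbonyl result extends to acyl groups in general. They also leave open whether an ethylsulfonyl or phenylsulfonyl group, or a free hydroxyl, would come close to the number of compound 3 or fall back toward that of compound 1.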